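Ester variation on a dihydropyridine imidazole series

The source may report more compounds than this note shows. Statements on the series, on what has been measured and on what is new or still open speak of the compounds shown alone.

Compound 1 `CCc1nc(Cl)c(C2C(C(=O)OC)=C(C)NC(C)=C2C(=O)OC)[nH]1` is the dimethyl ester of the shared core; in an assay on ileum for inhibition of Voltage-dependent L-type calcium channel subunit alpha-1C (Cavia porcellus) (a higher number here means a weaker inhibitor, a lower number a stronger inhibitor), compound 1 gives 0.596 nM. Compound 2 `CCc1nc(Cl)c(C2C(C(=O)OC)=C(C)NC(C)=C2C(=O)OCc2ccccc2)[nH]1` carries a benzyl ester and in this assay compound 2 gives 1.75 nM. The change hydrogen in place of phenyl on a saturated chain carbon bound to an oxygen next to a carbonyl group gives a 2.9-fold lower number from compound 2 to compound 1 (0.47 log units; beyond the scatter). Compound 3 `CCc1nc(C2C(C(=O)OCCc3ccccc3)=C(C)NC(C)=C2C(=O)OCCc2ccccc2)c(Cl)[nH]1` carries two phenethyl esters; in this assay compound 3 gives 0.0437 nM, the lowest number of the three. The difference between the cores of compound 3 and compound 2 is not broken down here.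

Compound 4 `CCOC(=O)C1=C(C)NC(C)=C(C(=O)OCCc2ccccc2)C1c1nc(CC)[nH]c1Cl` is not yet measured. Among the compounds with values here, the change hydrogen in place of phenyl on a saturated chain carbon, two bonds along the chain from an oxygen next to a carbonyl group is the same kind of change as the one from compound 2 to compound 1, but the place differs: there the hydrogen enters on a saturated chain carbon bound to an oxygen next to a carbonyl group, here on a saturated chain carbon two bonds along the chain from an oxygen next to a carbonyl group. Given that compound 3 lies far below compound 1, which gives 0.596 nM, the step is expected to be a 1.6-fold higher number from compound 3 to compound 4 (0.20 log units; within the scatter). Compound 4 is estimated at 0.07 nM, between 0.02 nM and 0.3 nM.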

Compound 4, half-maximal inhibitory concentration: 0.0457 nM
Beside the measured number, compound 4's estimate is 1.5-fold (0.19 log units) above it; the range from low to high includes it.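

In this assay, the phenethyl to ethyl change on the core of compound 3 gives a 1.0-fold higher number from compound 3 to compound 4 (0.02 log units; within the scatter), so removing this phenyl leaves the result within the scatter. Set beside the benzyl to methyl change, the same kind of change does not carry over at one size in this series: the same change on two cores in this assay, a 2.9-fold lower number (0.47 log units; beyond the scatter) from compound 2 to compound 1 and a 1.0-fold higher number (0.02 log units; within the scatter) from compound 3 to compound 4, 3.1-fold (0.49 log units) apart, beyond the scatter of two such steps

A step read on one core is therefore a poor guide to the step on another here, but two pairs cannot separate the core from the place, as the hydrogen enters on a different chain carbon in each pair and the second ester differs as well.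

Still open, going by these compounds, is whether phenethyl to ethyl gives a similar step when the second ester is methyl, which would test the place apart from the rest of the core. Also open, on these data alone, is how this assay responds to a longer chain ending in phenyl, or to an ester chain carrying an amine.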